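Trading the fluorophenyl ring for trifluoromethyl: an exposure estimate

The source may report more compounds than this note shows. Statements on the series, on what has been measured and on what is new or still open speak of the compounds shown alone.

Compound 1 `O=C(Nc1ccc(F)c(-c2nc3ncc(-c4ccccc4F)cc3[nH]2)c1)N1CCCC1` is the reference point. For the measured compounds named here, in an ADME assay on the whole organism (Mus musculus, strain Swiss Webster) for pharmacokinetics, read by LC-MS, at a dose of 50 mg/kg by the oral route (on this read-out lower numbers stand for lower exposure and higher numbers for higher exposure at the dose given), compound 1 gives 2230 nM, the highest of the three numbers measured so far. Compound 3 `O=C(Nc1ccc(F)c(-c2nc3ncc(-c4cccc(F)c4F)cc3[nH]2)c1)N1CCCC1` gives 1830 nM, and the step of a 1.2-fold lower number from compound 1 to compound 3 (0.09 log units; within the scatter) lies within the scatter. Compound 2 `O=C(Nc1ccc(F)c(-c2nc3ncc(-c4cncc(F)c4)cc3[nH]2)c1)N1CCCC1` gives 1070 nM, and the step of a 2.1-fold lower number from compound 1 to compound 2 (0.32 log units; beyond the scatter) is the only one that lies beyond the scatter.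

Compound 4 `O=C(Nc1ccc(F)c(-c2nc3ncc(C(F)(F)F)cc3[nH]2)c1)N1CCCC1` has not yet been measured. Its change from compound 1 is trifluoromethyl in place of 2-fluorophenyl on an aromatic carbon. The measured steps all alter this same group on the shared core: the step of a 2.1-fold lower number from compound 1 to compound 2 (0.32 log units; beyond the scatter) exchanges one ring for another ring, the step of a 1.2-fold lower number from compound 1 to compound 3 (0.09 log units; within the scatter) puts fluoro in place of hydrogen on that ring, and neither moves the number far. Going by the values given here, the change to trifluoromethyl removes the ring altogether, so no measured step matches it closely; the measured steps only show that alterations at this position have so far stayed modest. The expectation is therefore a small step in this assay, possibly in either direction, and most likely within the scatter. Compound 4 is expected to give 2000 nM, with a range from 700 nM to 5500 nM. The expected step is a 1.1-fold lower number from compound 1 to compound 4 (0.05 log units; within the scatter).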

Compound 4, maximal plasma concentration: 1080 nM
Compound 4: the middle estimate sits 1.9-fold (0.27 log units) above what was measured; measured number inside the range.
By their numbers in this assay, from the lowest: compounds 2, 4, 3 and 1 (each within the scatter of the next, the first and the last beyond it).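

For the compounds shown here, compound 4 shows what the earlier compounds could not: this position can lose its ring entirely, and the exposure number stays measurable and of a similar size, with a 2.1-fold lower number from compound 1 to compound 4 (0.31 log units; beyond the scatter) counting as only a modest step. Replacing the ring with trifluoromethyl therefore has about the same effect on the number as replacing 2-fluorophenyl with 5-fluoropyridin-3-yl, since a 1.0-fold higher number from compound 2 to compound 4 (0.00 log units; within the scatter) and the two compounds cannot be told apart in this assay; compound 3 also stays within the scatter of compound 4 (a 1.7-fold lower number from compound 3 to compound 4 (0.23 log units; within the scatter)), so the change does not separate compound 4 from either ring-bearing neighbour, only from compound 1. Nothing available explains why the number moves as it does for this change, and exposure at a single oral dose does not reveal which step of uptake or clearance is involved.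

Every group shown at this position is either a fluorinated ring or trifluoromethyl, so it remains open how a group without fluorine, such as a plain methyl or a longer alkyl chain, would behave. Going by these compounds, an amine or a carboxylic acid at the same place is equally open, and these would show how far the tolerance seen here extends.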